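The compounds below may be only part of what the source reports. "The series", "measured", "known", "first", "only" and "open" are said of these compounds alone.

Compound 1 `CC1CCN(C2CCN(S(=O)(=O)c3cccc(Br)c3)CC2)CC1` gives > 5000 nM in an ADME assay on HCT-116 cells (Homo sapiens) for cytotoxicity, read by CellTiter-Glo, with a stated time of 72 h (a lower number here means a stronger inhibitor, a higher number a weaker inhibitor), which is a limit of the assay. Compound 2 `Cc1ccc(-c2cccc(S(=O)(=O)N3CCC(N4CCC(C)CC4)CC3)c2)cc1` gives > 5000 nM in this assay, again a limit. Compound 3 `Cc1cc(C)cc(-c2cccc(S(=O)(=O)N3CCC(N4CCC(C)CC4)CC3)c2)c1` gives > 5000 nM in this assay, also a limit.

Compound 1 therefore stands at the assay limit, where all three values sit (the limit of > 5000 nM in this assay, at which 3 of the 3 values shown sit). Compound 4 `CC1CCN(C2CCN(S(=O)(=O)c3ccccc3Br)CC2)CC1` differs from compound 1 by 2-bromophenyl in place of 3-bromophenyl on a sulfonyl sulfur. The measured steps a step that the two limits leave unreadable from compound 1 to compound 2, a step that the two limits leave unreadable from compound 1 to compound 3 and a step that the two limits leave unreadable from compound 2 to compound 3 are all unreadable because every value is a limit (the limit of > 5000 nM in this assay, at which 3 of the 3 values shown sit), and none of them moves the bromine; none bears directly on this change. With no readable step, compound 4 is expected to remain at the limit, a step that the limit leaves unreadable from compound 1 to compound 4. Compound 4 is estimated at 8000 nM, between 3000 nM and 30000 nM.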

Compound 4, half-maximal inhibitory concentration: > 5000 nM
Compound 4 ended at the assay's limit; the forecaster's own chance of this, stated with the estimate: 85%; the middle value is on the limit's open side.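

No step from compound 1 to compound 4 can be read, because both values are limits: the limit of > 5000 nM in this assay, at which 4 of the 4 values shown sit.

The compounds shown leave open how far each lies past that limit, and whether 2-bromophenyl and 3-bromophenyl differ at all in this assay.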